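Ester to acid on the amide-side chain of compound 3

The compounds below may be only part of what the source reports. "The series", "measured", "known", "first", "only" and "open" are said of these compounds alone.

Compound 1 `CCn1c(C(=O)NCCCN(C)C)ccc1C(CC)(CC)c1ccc(OCCC(O)(CC)CC)c(C)c1` carries a (dimethylamino)methyl-terminated chain on its amide-type nitrogen; in an assay on cells for agonist activity at vitamin D3 receptor (Homo sapiens), with a stated time of 96 h (a lower number here means that less compound is needed, a higher number that more compound is needed for the effect), compound 1 gives 5 nM. Compound 2 `CCn1c(C(=O)NCCN(C)C)ccc1C(CC)(CC)c1ccc(OCCC(O)(CC)CC)c(C)c1` shortens that chain, and in this assay compound 2 gives 82 nM, a step described as a 16-fold higher number from compound 1 to compound 2 (1.21 log units; beyond the scatter). Compound 3 `CCC(C)C(NC(=O)c1ccc(C(CC)(CC)c2ccc(OCCC(O)(CC)CC)c(C)c2)n1CC)C(=O)OC` replaces the amine-bearing chain with a group of nine heavy atoms that holds a methoxycarbonyl. In this assay compound 3 reaches only the limit of the assay, > 10000 nM, as noted in the limit of > 10000 nM in this assay, at which 1 of the 3 values shown sits. The steps of an at least 2000-fold higher number from compound 1 to compound 3 (3.30 log units; beyond the scatter) and an at least 120-fold higher number from compound 2 to compound 3 (2.08 log units; beyond the scatter) therefore only set a floor: compound 3 stands beyond the range in which numbers are returned.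

Compound 4 `CCC(C)C(NC(=O)c1ccc(C(CC)(CC)c2ccc(OCCC(O)(CC)CC)c(C)c2)n1CC)C(=O)O` differs from compound 3 by hydrogen in place of methyl on an oxygen next to a carbonyl group, that is, methoxycarbonyl to carboxy. Within the data shown here, no measured step in this assay exchanges ester for acid, so the only bearing evidence is the position of compound 3 itself. Compound 4 keeps the nine-atom group and lacks the amine chain of compound 1 and compound 2, so the expected step in this assay is a step that the limit leaves unreadable from compound 3 to compound 4, no move beyond the scatter. Compound 4 is accordingly expected to give about 15000 nM in this assay, within 3000 nM to 60000 nM, most likely reported again as a limit.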

Compound 4, half-maximal effective concentration: 860 nM
Beside the measured number, compound 4's estimate is 17-fold (1.24 log units) above it, outside the stated range (below it).
By their numbers in this assay, from the lowest: compound 1; then compound 2; then compound 4. At a limit, above all of these: compound 3.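

In this assay the change from methoxycarbonyl to carboxy turns a limit into a measurable number, an at least 11-fold lower number from compound 3 to compound 4 (1.06 log units; beyond the scatter), so this position can give a read-out without an amine on the chain, and a change of one methyl to hydrogen on the oxygen is enough to produce it. The size of that step is only a floor, since compound 3 stands at a limit: the limit of > 10000 nM in this assay, at which 1 of the 4 values shown sits. The carboxy compound still stays behind both amine-bearing compounds, with a 10-fold higher number from compound 2 to compound 4 (1.02 log units; beyond the scatter) and a 170-fold higher number from compound 1 to compound 4 (2.24 log units; beyond the scatter), and as each of these steps exchanges the whole group on the amide-type nitrogen, they rank the groups without isolating the effect of the carboxy.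

The compounds shown leave open whether the carboxy itself is required, or whether a primary amide or a hydroxymethyl on the same branched group would also give a measurable number. They also leave open how a carboxy fares on an unbranched chain such as 3-carboxypropyl, which would separate the acid from the 2-methylbutyl part and allow a direct comparison with the 3-(dimethylamino)propyl chain of compound 1.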